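The source may hold more compounds than are shown below. What is called first, only, known or untested is meant among the compounds shown, and "the series" means these compounds.

Within the data shown here, compound 2 `Cc1ccc(S(=O)(=O)N2N=C(c3ccc(-n4cncn4)cc3)CC2c2ccc(N(C)C)cc2)cc1` stands highest of the two numbers so far in a functional assay on NCI-H1975 cells (Homo sapiens) for inhibition, read by sulforhodamine B assay, tested at 10 uM (on this read-out lower numbers stand for less inhibition and higher numbers for more inhibition at the one concentration tested (going by the name of the read-out)), where compound 2 gives 20%. Among the measured compounds shown here, compound 1 `CN(C)c1ccc(C2CC(c3ccc(-n4cncn4)cc3)=NN2C(=O)CCCl)cc1` gives -0.7% in this assay, and the one measured step is a number 20.7 percentage points higher from compound 1 to compound 2 (beyond the scatter). Compound 3 `CN(C)c1ccc(C2CC(c3ccc(-n4cncn4)cc3)=NN2S(=O)(=O)c2ccc(C(F)(F)F)cc2)cc1` differs from compound 2 by trifluoromethyl in place of methyl on an aromatic carbon. For the measured compounds named here, that measured step concerns the group on an amine nitrogen in a ring and so does not bear on this change; no step on the aromatic ring is available. The account therefore expects no step beyond the scatter, no change at the digits printed from compound 2 to compound 3 (within the scatter), and estimates compound 3 at 20%, between 5% and 35%.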

Compound 3, a percentage reported as inhibition, at one concentration (the size of the read-out at that concentration, not a potency): 5.5%
Estimate against measurement, compound 3: 14.5 percentage points above; the range from low to high includes it.
By their numbers in this assay, from the lowest: compounds 1 and 3 (each within the scatter of the next); then compound 2.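

In this assay, the group on this aromatic carbon matters, since trifluoromethyl in place of methyl gives a number 14.5 percentage points lower from compound 2 to compound 3 (beyond the scatter). The higher number of compound 2 therefore does not carry over to every arylsulfonyl group: compound 3 lies within the scatter of compound 1, which has the (2-chloroethyl)carbonyl group instead. Nothing measured here offers an explanation for this difference. On these data alone, what remains open is how a methoxy group, a chlorine atom or an amine at this place would read, and whether any such group would stand above compound 2.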